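The compounds below may be only part of what the source reports. "The series", "measured", "known", "first", "only" and "open" are said of these compounds alone.

Measured compounds:
Compound 1 `O=C1O[C@@H](CN2CCC(O)CC2)CN1c1ccc(-n2cc(-c3ccccn3)cn2)c(F)c1`: in an ADME assay on HEK293-A cells (Homo sapiens) for cytotoxicity, read by MTT assay, with a stated time of 48 h (a higher number here means a weaker inhibitor, a lower number a stronger inhibitor), compound 1 gives > 400 ug/mL, which is a limit of the assay and not a number.
Compound 2 `CCC(=O)NC[C@H]1CN(c2ccc(-n3cc(-c4ccccn4)cn3)c(F)c2)C(=O)O1`: in this assay compound 2 gives 389 ug/mL.

For the measured compounds named here, compound 2 holds the only number in this assay; the other value shown is a limit. Going by the values given here, the one measured step, an at least 1.0-fold lower number from compound 1 to compound 2 (0.01 log units; that floor lies within the scatter), lies within the scatter and is bounded by the limit of > 400 ug/mL in this assay, at which 1 of the 2 values shown sits. Compound 3 `COC(=O)NC[C@H]1CN(c2ccc(-n3cc(-c4ccccn4)cn3)c(F)c2)C(=O)O1` differs from compound 2 by methoxy in place of ethyl on a carbonyl carbon. Among the compounds with values here, no measured step touches that carbonyl carbon, and the only step known, from compound 1 to compound 2, showed nothing beyond the scatter, so no shift beyond the scatter is expected here either. Compound 3 is therefore estimated at 380 ug/mL, with a range of 190 ug/mL to 400 ug/mL. This estimate amounts to a step of a 1.0-fold lower number from compound 2 to compound 3 (0.01 log units; within the scatter), with a real chance that the assay again reports only its limit.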

Compound 3, half-maximal inhibitory concentration: 306 ug/mL
Compound 3: the middle estimate sits 1.2-fold (0.09 log units) above what was measured, and the stated range covers the measured number.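

In this assay, for the compounds shown here, this is the first change made at the carbonyl carbon itself, and methoxy in place of ethyl gives a 1.3-fold lower number from compound 2 to compound 3 (0.10 log units; within the scatter), so compound 2 and compound 3 cannot be told apart here. Comparing the (methoxycarbonyl)amino group with 4-hydroxypiperidin-1-yl on the saturated chain carbon gives an at least 1.3-fold lower number from compound 1 to compound 3 (0.11 log units; that floor lies within the scatter), so this comparison also shows no difference that can be relied on. That step is only a floor, because compound 1 carries a limit and not a number: the limit of > 400 ug/mL in this assay, at which 1 of the 3 values shown sits.

The compounds shown leave open whether any group on this carbonyl carbon can move the number beyond the scatter. A longer chain such as butyl, or an amine such as dimethylamino, in place of ethyl or methoxy would test that.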